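Sulfonamide series: imidazolylmethyl sulfonyl variant of compound 2

The source may hold more compounds than are shown below. What is called first, only, known or untested is meant among the compounds shown, and "the series" means these compounds.

Measured so far:
compound 1, `CCCCc1ccc(CN(CCCOc2cccc(C(=O)O)c2)S(C)(=O)=O)cc1`, 3130 nM
compound 2, `CC(C)(C)c1ccc(CN(Cc2cccc(OCC(=O)O)c2)S(C)(=O)=O)cc1`, 792 nM

In an assay on HEK293 cells for inhibition of prostaglandin E2 receptor EP2 subtype (Rattus norvegicus) (a higher number here means a weaker inhibitor, a lower number a stronger inhibitor), compound 1 gives 3130 nM. In this assay compound 2 gives 792 nM, the lowest of the two numbers; compound 1 stands higher, beyond the scatter. Among the measured compounds shown here, the two differ in more than one place, so no single step is counted between them.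

Compound 3, `Cn1ccnc1CS(=O)(=O)N(Cc1ccc(C(C)(C)C)cc1)Cc1cccc(OCC(=O)O)c1`, is not yet measured. It differs from compound 2 in one place: 1-methyl-1H-imidazol-2-yl in place of hydrogen on a saturated chain carbon bound to a sulfonyl sulfur. For the measured compounds named here, no measured pair shows this change, so its size is unknown from the series. The expectation is a step of modest size from compound 2 to compound 3 of a 1.3-fold lower number from compound 2 to compound 3 (0.12 log units; within the scatter) in this assay, likely within or just beyond the scatter, direction uncertain. Compound 3 is therefore estimated at 600 nM, with a range of 200 nM to 2000 nM.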

Compound 3, half-maximal inhibitory concentration: 326 nM
Compound 3: the middle estimate sits 1.8-fold (0.26 log units) above what was measured, and the stated range covers the measured number.
By their numbers in this assay, from the lowest: compound 3; then compound 2; then compound 1.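

In this assay, the saturated chain carbon bound to the sulfonyl sulfur tolerates substitution: placing 1-methyl-1H-imidazol-2-yl on it in place of hydrogen gives a 2.4-fold lower number from compound 2 to compound 3 (0.39 log units; beyond the scatter) and stays beyond the scatter. Among the compounds shown here, compounds 1 and 2 both carry the plain methylsulfonyl group, so this is the first reading of any change at this place, and it shows that ((1-methyl-1H-imidazol-2-yl)methyl)sulfonyl is accepted there without loss. No measurement shown here offers a reason for the step.

As far as these compounds go, whether the step depends on the imidazole ring itself stays open, since a phenyl or pyridin-2-yl group at the same carbon would separate the ring from mere added size, and an imidazol-2-yl group without the methyl would test that methyl. From the compounds shown here alone, it is also open whether the same change would carry over to the core of compound 1.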